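A few compounds are considered here, and "the series" means these few. Any claim that something is new, unique, unknown or untested is made for them only; others in the source may bear on it.

Measured compounds:
- compound 1 `O=C(CNC(=O)c1nn(-c2ccc(F)cc2)c(=O)c2ccccc12)Nc1nc2ccccc2s1` — in an assay on L cells for inhibition of Protein-serine O-palmitoleoyltransferase porcupine (Mus musculus), read by reporter gene assay, with a stated time of 24 h (a lower number here means that less compound is needed, a higher number that more compound is needed for the effect), it sits at a limit, > 25000 nM
- compound 2 `O=C(CNC(=O)c1nn(-c2ccccc2)c(=O)c2ccccc12)Nc1nc2ccc(C(F)(F)F)cc2s1` — in this assay compound 2 gives 110 nM
- compound 3 `O=C(CNC(=O)c1nn(-c2ccccc2)c(=O)c2ccccc12)Nc1nc2ccc(F)cc2s1` — in this assay compound 3 gives 470 nM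

Compound 2 holds the lowest of the two numbers in this assay; the nearest is compound 3, with a 4.3-fold higher number from compound 2 to compound 3 (0.63 log units; beyond the scatter). Compound 1 is a limit only, (the limit of > 25000 nM in this assay, at which 1 of the 3 values shown sits).

Compound 4 `O=C(CNC(=O)c1nn(-c2ccc(F)cc2)c(=O)c2ccccc12)Nc1nc2ccc(C(F)(F)F)cc2s1` differs from compound 2 by fluoro in place of hydrogen on an aromatic carbon. Within the data shown here, no measured step isolates this change: compound 1 and compound 3 differ in two places, so only their values can be noted, and the step of a 4.3-fold higher number from compound 2 to compound 3 (0.63 log units; beyond the scatter) concerns the other ring. A modest step of a 2.0-fold higher number from compound 2 to compound 4 (0.30 log units; within the scatter) is therefore expected, with wide uncertainty. Compound 4 is estimated at 220 nM, between 60 nM and 1500 nM.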

Compound 4, half-maximal effective concentration: 90 nM
For compound 4 the middle estimate is 2.4-fold (0.39 log units) above the measured one; low and high end bracket the measured number.
By their numbers in this assay, from the lowest: compounds 4 and 2 (each within the scatter of the next); then compound 3. At a limit, above all of these: compound 1.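

Replacing phenyl with 4-fluorophenyl makes no real difference when trifluoromethyl is present (a 1.2-fold lower number from compound 2 to compound 4 (0.09 log units; within the scatter)). Compound 1 carries the same 4-fluorophenyl, so this group alone does not go with a loss of activity, and adding trifluoromethyl on the other ring brings a large drop in the number (an at least 270-fold lower number from compound 1 to compound 4 (2.44 log units; beyond the scatter)). Compound 1 gives a limit, not a true number: the limit of > 25000 nM in this assay, at which 1 of the 4 values shown sits.

The compounds shown leave open how chloro, methoxy or an amine would fare in the fluoro's place. They also leave open whether fluoro makes as little difference without trifluoromethyl.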